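Replacing a fused bicyclic amine with a pyrrolidinylamino group

This account rests on a few compounds, and the source may have more. Where it says the series, first, only, none or still open, it means among the compounds named here.

Measured so far:
compound 1, `CCCN(Cc1cn2c(N3CCN(C)CC3)cccc2n1)[C@H]1CCCc2cccnc21`: 6700 nM
compound 2, `CN(Cc1cn2c(N3CCN4CCCC4C3)cccc2n1)[C@H]1CCCc2cccnc21`: 3900 nM

Of the compounds shown here, two have been tested in an ADME assay on HOS cells (Homo sapiens) for cytotoxicity; a lower number here means that less compound is tolerated, a higher number that more compound is tolerated. Compound 1 gives 6700 nM and compound 2 gives 3900 nM; the gap between them lies within the usual scatter of this assay, so the two cannot be told apart, and compound 2 simply serves as the starting point of the step considered here. Within the data shown here, since no step between measured compounds is available, there is nothing to calibrate the effect of a structural change on cytotoxicity.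

Compound 3, `CN1CCC(N(C)c2cccc3nc(CN(C)[C@H]4CCCc5cccnc54)cn23)C1`, has not yet been measured in this assay. It differs from compound 2 in one place: a group of 8 heavy atoms (6 carbon, 2 nitrogen; one five-membered non-aromatic ring with 1 hetero atom) in place of a group of 9 heavy atoms (7 carbon, 2 nitrogen; one five-membered non-aromatic ring with 1 hetero atom, one six-membered non-aromatic ring with 2 hetero atoms), on an aromatic carbon. Both groups share a five-membered non-aromatic ring with one hetero atom, with no change in donors, acceptors or charge.

Among the measured compounds shown here, with no measured step to lean on, the expected change is none beyond the scatter, and the estimated step of a 1.2-fold higher number from compound 2 to compound 3 (0.06 log units; within the scatter) reflects that. Compound 3 is therefore expected to give about 4500 nM in this assay, with a range from 1500 nM to 13000 nM.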

Compound 3, half-maximal cytotoxic concentration: 10800 nM
Compound 3: the middle estimate sits 2.4-fold (0.38 log units) below what was measured; the measured number falls inside the stated range.
By their numbers in this assay, from the lowest: compounds 2, 1 and 3 (each within the scatter of the next, the first and the last beyond it).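

In this assay, among these compounds, putting methyl(1-methylpyrrolidin-3-yl)amino in place of the group carrying a five-membered and a six-membered non-aromatic ring gives a 2.8-fold higher number from compound 2 to compound 3 (0.44 log units; beyond the scatter), a modest change but the first single-place step here that stands beyond the scatter. It shows that this aromatic carbon, next to the ring nitrogen, is a place where the choice of amine group can shift how much compound the cells tolerate, even though the two groups have the same counts of hydrogen-bond donors and acceptors and neither carries a net charge. No measurement offered here explains the shift.

This single step cannot separate the loss of the six-membered non-aromatic ring from the other differences between the two groups, including the methyl-bearing nitrogen that now joins the five-membered ring to the aromatic carbon. Going by these compounds, what a morpholine or an open-chain dimethylamino group would do at this carbon remains open, as does whether the same change would have a similar effect with a propyl group in place of the methyl on the amine outside the core.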